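The source may report more compounds than this note shows. Statements on the series, on what has been measured and on what is new or still open speak of the compounds shown alone.

For the measured compounds named here, compound 2 `Cc1cnc(C[S+]([O-])C(c2ccccc2)c2ccccc2)nc1` gives 156000 nM in an assay on HEK293 cells for inhibition of sodium-dependent dopamine transporter (Homo sapiens), read by scintillation counting, with stated times of 5 min and 1 min (a higher number here means a weaker inhibitor, a lower number a stronger inhibitor), the higher of the two numbers so far; compound 1 `CC(C)c1nnsc1C[S+]([O-])C(c1ccccc1)c1ccccc1` gives 69100 nM, and the step of a 2.3-fold higher number from compound 1 to compound 2 (0.35 log units; beyond the scatter) was the only one seen. Compound 3 `Cc1nnc(C[S+]([O-])C(c2ccccc2)c2ccccc2)s1` carries 5-methyl-1,3,4-thiadiazol-2-yl in place of 5-methylpyrimidin-2-yl on a saturated chain carbon bound to a sulfur. Going by the values given here, the one measured step bears on it only loosely, since it also put a five-membered ring in place of a six-membered one, and its size was modest. Compound 3 is therefore expected to return part of that way, with a step of a 1.7-fold lower number from compound 2 to compound 3 (0.24 log units; within the scatter), giving an estimated 90000 nM in this assay, within 35000 nM to 230000 nM.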

Compound 3, half-maximal inhibitory concentration: "not active" (no number reported)
Nothing numeric was reported for compound 3, so the estimate cannot be set against anything.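

For the compounds shown here, compound 3 was reported as not active in this assay with no number, so no step from compound 2 can be read, and no measured evidence bears on this result. Going by these compounds, how far the 5-methyl-1,3,4-thiadiazol-2-yl group in compound 3 shifts inhibition relative to compound 2 stays open.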